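Swapping the amine ring at the end of the propoxy chain

The source may hold more compounds than are shown below. What is called first, only, known or untested is meant among the compounds shown, and "the series" means these compounds.

Compound 1 `COc1cc2c(Nc3nc4ccc(C(=O)Nc5c(C)cc(C)cc5C)cc4s3)ncnc2cc1OCCCN1CCC(C)CC1` gives the lowest of the three numbers measured in a functional assay on K562 cells (Homo sapiens) for cytotoxicity, read by WST assay, with a stated time of 72 h (on this read-out higher numbers stand for weaker inhibition and lower numbers for stronger inhibition), with compound 1 at 5900 nM. Compound 3 `COc1cc2c(Nc3nc4ccc(C(=O)Nc5c(C)cccc5Cl)cc4s3)ncnc2cc1OCCCN1CCC(C)CC1` gives 8300 nM, and a 1.4-fold higher number from compound 1 to compound 3 (0.15 log units; within the scatter). Compound 2 `COc1cc2c(Nc3nc4ccc(C(=O)Nc5c(C)cccc5C)cc4s3)ncnc2cc1OCCCN1CCCCC1` differs from compound 1 in two places; in this assay compound 2 gives 13700 nM. Compound 4 `COc1cc2c(Nc3nc4ccc(C(=O)Nc5c(C)cc(C)cc5C)cc4s3)ncnc2cc1OCCCN1CCCC1` has not been measured; it carries pyrrolidin-1-yl in place of 4-methylpiperidin-1-yl on a saturated chain carbon, three bonds along the chain from an oxygen on an aromatic ring. No measured step changes only this amine ring, so nothing here indicates the direction of the change, and the only step shown, from compound 1 to compound 3, stays within the scatter. Compound 4 is therefore expected to stay close to compound 1, with a 1.4-fold higher number from compound 1 to compound 4 (0.13 log units; within the scatter), and an estimated value of 8000 nM, ranging from 3000 nM to 22000 nM.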

Compound 4, half-maximal inhibitory concentration: 4300 nM
Estimate against measurement, compound 4: 1.9-fold (0.27 log units) above; the range from low to high includes it.
By their numbers in this assay, from the lowest: compounds 4, 1, 3 and 2 (each within the scatter of the next, the first and the last beyond it).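

Within the data shown here, this is the first step that changes only the amine ring at the end of the propoxy chain. In this assay, pyrrolidin-1-yl in place of 4-methylpiperidin-1-yl gives a 1.4-fold lower number from compound 1 to compound 4 (0.14 log units; within the scatter), so the five-membered ring and the methyl-bearing six-membered ring cannot be told apart at this position. Nothing at hand explains this result.

Going by these compounds, it remains open whether a morpholine ring or an open-chain dimethylamino group would read the same at the end of this chain. A butoxy chain carrying the pyrrolidine ring is also untested among the compounds shown.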